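The source may report more compounds than this note shows. Statements on the series, on what has been measured and on what is new or still open speak of the compounds shown alone.

Measured compounds:
compound 1, `Cc1cc(C(=O)Nc2ccccc2)nn1Cc1cc(Cl)ccc1OCc1ccccc1`: 39.8 nM
compound 2, `Cc1cc(C(=O)Nc2ccc(F)cc2)nn1Cc1cc(Cl)ccc1OCc1ccccc1`: 79.4 nM

Both compounds were tested in an assay on CHO-K1 cells for displacement of a labelled ligand from prostaglandin E2 receptor EP1 subtype (Homo sapiens); on this read-out lower numbers stand for stronger inhibition and higher numbers for weaker inhibition. Among the compounds with values here, of the two numbers, compound 2 gives the higher one, with compound 1 as its only neighbour; the single step between them, a 2.0-fold higher number from compound 1 to compound 2 (0.30 log units; within the scatter), is a fluoro in place of hydrogen on an aromatic carbon, and it lies within the scatter of this assay.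

Compound 3, `Cc1cc(C(=O)Nc2c(F)cccc2F)nn1Cc1cc(Cl)ccc1OCc1ccccc1`, has not yet been measured. Its difference from compound 2 is 2,6-difluorophenyl in place of 4-fluorophenyl on an amide-type nitrogen. Within the data shown here, the only measured step that bears on this change is the one adding a fluoro to the same ring, and that step stayed within the scatter. Nothing measured here shows what two fluoro groups on this ring do, so the expectation for compound 3 is a step of a 1.0-fold higher number from compound 2 to compound 3 (0.00 log units; within the scatter), which is to say no movement beyond the scatter, with the range kept wide to reflect the thin evidence. Compound 3 is therefore estimated at 80 nM in this assay, within a range from 30 nM to 250 nM.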

Compound 3, half-maximal inhibitory concentration: 10 nM
Estimate against measurement, compound 3: 8.0-fold (0.90 log units) above, and the stated range ends above it.
By their numbers in this assay, from the lowest: compound 3; then compounds 1 and 2 (each within the scatter of the next).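

Within the data shown here, putting 2,6-difluorophenyl in place of 4-fluorophenyl on the amide-type nitrogen gives a 7.9-fold lower number from compound 2 to compound 3 (0.90 log units; beyond the scatter) in this assay, the first step in this small set to go beyond the scatter, so this ring is not indifferent to how it is substituted. Set against the plain phenyl group, the same 2,6-difluorophenyl group gives a 4.0-fold lower number from compound 1 to compound 3 (0.60 log units; beyond the scatter), so it stands apart from both earlier rings, whereas the earlier swap of phenyl for 4-fluorophenyl stayed within the scatter. Nothing measured here explains why the number drops with this group.

This change alters both how many fluoro groups the ring carries and where they sit, so the compounds shown cannot separate these two effects. They also leave open whether other groups in place of the two fluoro groups, such as chloro, methyl or methoxy, would give a similarly low number, and whether the drop would persist if the rest of the shared core were changed.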